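Swapping imidazolyl for pyridinyl on compound 1

The source may report more compounds than this note shows. Statements on the series, on what has been measured and on what is new or still open speak of the compounds shown alone.

Compound 1 `CNC(=O)[C@@H]1CCCN1S(=O)(=O)c1ccc(Cl)c(COc2cccc3c(-n4ccnc4)cc(C)nc23)c1Cl` gives 267 mL/min/kg
Compound 2 `Cc1cc(C(F)(F)F)c2cccc(OCc3c(Cl)ccc(S(=O)(=O)N4CC[C@@H](N(C)C)C4)c3Cl)c2n1` gives 867 mL/min/kg
Compound 3 `Cc1cc(C(F)(F)F)c2cccc(OCc3c(Cl)ccc(S(=O)(=O)N4CCC(CCO)CC4)c3Cl)c2n1` gives 1080 mL/min/kg

These numbers come from an ADME assay on microsomes (Mus musculus) for metabolic stability (on this read-out lower numbers stand for slow clearance and higher numbers for fast clearance), and compound 1 has the lowest of the three, with both others beyond the scatter above it. Compound 4 `CNC(=O)[C@@H]1CCCN1S(=O)(=O)c1ccc(Cl)c(COc2cccc3c(-c4ccccn4)cc(C)nc23)c1Cl` keeps the rest of compound 1 but carries pyridin-2-yl in place of 1H-imidazol-1-yl on an aromatic carbon opposite the ring nitrogen. Among the measured compounds shown here, no measured pair isolates this swap. For the measured compounds named here, the one measured step, a 1.2-fold higher number from compound 2 to compound 3 (0.10 log units; within the scatter), concerns a different group on a sulfonyl sulfur, so it bears only loosely on this change. Compound 2 at 867 mL/min/kg and compound 3 at 1080 mL/min/kg lack the imidazolyl group but also differ from compound 1 elsewhere, so they hint weakly at an upward direction. The estimated change is a 1.4-fold higher number from compound 1 to compound 4 (0.15 log units; within the scatter) in this assay and is expected to be a small rise within the scatter. For compound 4 an estimated 380 mL/min/kg is expected, with a range of 170 mL/min/kg to 800 mL/min/kg as its likely span.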

Compound 4, clearance: 733 mL/min/kg
Beside the measured number, compound 4's estimate is 1.9-fold (0.29 log units) below it; the measured number falls inside the stated range.
By their numbers in this assay, from the lowest: compound 1; then compounds 4, 2 and 3 (each within the scatter of the next).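

In this assay, pyridin-2-yl in place of 1H-imidazol-1-yl, on the aromatic carbon opposite the ring nitrogen, gives a 2.7-fold higher number from compound 1 to compound 4 (0.44 log units; beyond the scatter). Among the compounds shown here, this is the first measured step at this position, and it shows that changing this one group, with the rest of compound 1 held fixed, can move the number beyond the usual scatter, whereas the earlier step concerned only a group on a sulfonyl sulfur. Nothing measured here accounts for the rise, so its cause remains unknown.

On these data alone, how a pyrazole ring, a nitrile or a simple amine at this position would compare with these two groups remains open. So does whether the same swap would give a step of similar size with a different group on the sulfonyl sulfur.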